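From 2-Methylphenyl to 2-Bromophenyl: a Cytotoxicity Expectation

This account rests on a few compounds, and the source may have more. Where it says the series, first, only, none or still open, it means among the compounds named here.

Compound 1, `Cn1c(-c2cccc(Cl)c2)cnc1NC(=O)c1ccc(F)cc1`: > 50000 nM
Compound 2, `Cc1ccccc1-c1cnc(NC(=O)c2ccc(F)cc2)n1C`: > 50000 nM

In a toxicity assay on THP-1 cells (Homo sapiens) for inhibition (a lower number here means that less compound is tolerated, a higher number that more compound is tolerated), compound 1 reaches only the limit of the assay, > 50000 nM. Compound 2 likewise gives only a limit in this assay, > 50000 nM. The step that the two limits leave unreadable from compound 1 to compound 2 therefore cannot be read. Both values sit at the same boundary, as the evidence summarises: the limit of > 50000 nM in this assay, at which 2 of the 2 values shown sit.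

Compound 3, `Cn1c(-c2ccccc2Br)cnc1NC(=O)c1ccc(F)cc1`, is not yet measured. It differs from compound 2 by bromo in place of methyl on an aromatic carbon. Among the compounds with values here, no measured step bears on this change, and the only step available, from compound 1 to compound 2, was unreadable. With compound 2 at a limit of > 50000 nM, compound 3 is expected to stay near that boundary, with a step that the limit leaves unreadable from compound 2 to compound 3 meaning no shift beyond the scatter. Compound 3 is accordingly estimated at 60000 nM, within 20000 nM to 150000 nM, most likely reported again only as a limit.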

Compound 3, half-maximal cytotoxic concentration: > 100000 nM
Compound 3 was reported as a limit; the forecaster's own chance of this, stated with the estimate: 80%; at least 1.6-fold (0.22 log units) between middle value and limit.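

In this assay compound 3 gives > 100000 nM, which is a limit. Within the data shown here, no step among compound 1, compound 2 and compound 3 can be read. The compounds shown leave open whether exchanging 3-chlorophenyl, 2-methylphenyl and 2-bromophenyl changes the half-maximal cytotoxic concentration at all.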